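This account rests on a few compounds, and the source may have more. Where it says the series, first, only, none or still open, it means among the compounds named here.

Measured so far in a physicochemical assay for lipophilicity, read by HPLC, at pH 7.5; a higher number here means a more lipophilic compound, a lower number a more polar compound:

- compound 1 `CC[C@@H](Nc1c(C#N)c(-c2ccc(-c3ccccc3N(C)C)cc2)nc2cnccc12)C(N)=O` reads 3.2
- compound 2 `CC[C@@H](Nc1c(C#N)c(-c2ccc(-c3ccccc3COC)cc2)nc2cnccc12)C(N)=O` reads 2.6
- compound 3 `CC[C@@H](Nc1c(C#N)c(-c2ccc(-c3ccc(Cl)cc3)cc2)nc2cnccc12)C(N)=O` reads 3.1

Compound 3 stands level with compound 1, since the step is a number 0.10 log units lower from compound 1 to compound 3 (within the scatter). It stands clear of compound 2, with a number 0.50 log units higher from compound 2 to compound 3 (beyond the scatter).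

The next compound is compound 4 `CC[C@@H](Nc1c(C#N)c(-c2ccc(-c3ccccc3Cl)cc2)nc2cnccc12)C(N)=O`, which keeps the shared core and has 2-chlorophenyl in place of 4-chlorophenyl on an aromatic carbon. The group concerned sits para to a large group, and the same atoms are present in both compounds.

Going by the values given here, two measured steps bear on this change, as both alter the same aromatic substituent that differs here. One is a number 0.10 log units lower from compound 1 to compound 3 (within the scatter) and the other is a number 0.50 log units higher from compound 2 to compound 3 (beyond the scatter). So changing this substituent has given anything from no real shift to a modest one in this assay. Among the compounds with values here, neither step moves a chlorine, however, and the data hold no direct example of such a move. Within the data shown here, with the atoms unchanged, a shift as large as the one seen with compound 2 seems less likely than none, and no clear direction can be argued. The expected change is no change at the digits printed from compound 3 to compound 4 (within the scatter), which is none beyond the scatter. Compound 4 is estimated at 3.1, with an expected range from 2.8 to 3.4.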

Compound 4, distribution coefficient: 2.9
For compound 4 the middle estimate is 0.20 log units above the measured one, within the range that was stated.
By their numbers in this assay, from the lowest: compounds 2, 4, 3 and 1 (each within the scatter of the next, the first and the last beyond it).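

In this assay, the exchange of 4-chlorophenyl for 2-chlorophenyl, with the same atoms present, gives a number 0.20 log units lower from compound 3 to compound 4 (within the scatter), the first direct case of a chlorine moved on this ring, and the move brings no shift beyond the scatter. The chloro of compound 4 also reads level with both groups it can be set against on this carbon, with a number 0.30 log units higher from compound 2 to compound 4 (within the scatter) and a number 0.30 log units lower from compound 1 to compound 4 (within the scatter), even though those two groups stand apart, with a number 0.60 log units lower from compound 1 to compound 2 (beyond the scatter). Nothing in the data shown offers an explanation for these readings.

The compounds shown leave open whether a carboxylic acid or a primary amine in place of the chloro of compound 4 would read beyond the scatter from it, since every group seen so far on this ring carries no net charge in the comparison printed for the chlorophenyl pair and the others remain uncounted. They also leave open whether a fluoro or a bromo would read level with the chloro, and whether a longer ether chain would stay near methoxymethyl.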